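The source may report more compounds than this note shows. Statements on the series, on what has been measured and on what is new or still open speak of the compounds shown alone.

Compound 2 `Cc1cc(C)cc(Cc2ccc3c(NCCCNCc4ccco4)ccnc3c2)c1` is one of three close relatives measured in a physicochemical assay for solubility, with a stated time of 18 h, at pH 7.4; on this read-out lower numbers stand for lower solubility and higher numbers for higher solubility. In this assay compound 2 gives 4200 nM, level with compound 1 `COc1ccc(F)cc1CNCCCNc1ccnc2cc(Cc3ccc(C#N)cc3)ccc12` at 4200 nM and with compound 3 `COc1cccc(CNCCCNc2ccnc3cc(Cc4cc(C)cc(C)c4)ccc23)c1O` at 4200 nM. Among the compounds with values here, the one measured step, no change at the digits printed from compound 2 to compound 3 (within the scatter), alters the group on the saturated chain carbon bound to an amine nitrogen and stays within the scatter. Within the data shown here, compound 4 `Clc1ccc(Oc2ccc3c(NCCCNCc4ccco4)ccnc3c2)cc1` differs from compound 2 at another place, (4-chlorophenoxy in place of 3,5-dimethylbenzyl on an aromatic carbon), so no measured step bears directly on it; the scatter-sized step from compound 2 to compound 3 merely shows this series tolerates one change without moving. Compound 4 is therefore expected to shift only a 1.2-fold lower number from compound 2 to compound 4 (0.08 log units; within the scatter), and its solubility is estimated at 3500 nM, within 1200 nM to 10000 nM.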

Compound 4, solubility: 14500 nM
Compound 4: middle estimate off by 4.1-fold (0.62 log units), on the low side; the measured number lies above the stated range.
By their numbers in this assay, from the lowest: compounds 1, 2 and 3 (each within the scatter of the next); then compound 4.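

Within the data shown here, compound 4 shows that in this assay the number can move with a change on this aromatic carbon of the shared core, where the earlier compounds offered only a level comparison. Placing 4-chlorophenoxy there in place of 3,5-dimethylbenzyl gives a 3.5-fold higher number from compound 2 to compound 4 (0.54 log units; beyond the scatter) and so, unlike the change on the saturated chain carbon, this one leaves the scatter. The compounds shown do not separate the oxygen link from the chlorine, which 4-chlorobenzyl or 3,5-dimethylphenoxy on this carbon would do. Nothing shown gives a cause for this step.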